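The source may report more compounds than this note shows. Statements on the series, on what has been measured and on what is new or still open speak of the compounds shown alone.

Measured so far in a functional assay on A-375 cells (Homo sapiens) for inhibition, read by CCK-8 assay, with a stated time of 72 h, tested at 8 uM; on this read-out higher numbers stand for more inhibition of growth at the one concentration tested and lower numbers for less inhibition of growth:
- compound 1 `COc1ccc(SCc2ccc(/C=C/C(=O)Nc3ccccc3N)cc2)cc1OC`: 46.4%
- compound 2 `Nc1ccccc1NC(=O)/C=C/c1ccc(CSc2cccc(F)c2)cc1`: 9.08%
- compound 3 `CCc1ccc(SCc2ccc(/C=C/C(=O)Nc3ccccc3N)cc2)cc1`: 58.4%

All three share a core and differ only in the group on the sulfur. Compound 3 stands highest of the three, as shown by a number 12 percentage points higher from compound 1 to compound 3 (beyond the scatter) and a number 49.3 percentage points higher from compound 2 to compound 3 (beyond the scatter). The next compound, compound 4 `Nc1ccccc1NC(=O)/C=C/c1ccc(CSc2ccc(C(F)(F)F)cn2)cc1`, changes that same place: 5-(trifluoromethyl)pyridin-2-yl in place of 4-ethylphenyl on a sulfur.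

No ring with a hetero atom has yet been measured on the sulfur, so the evidence is indirect. The swap of groups on the sulfur has already moved this read-out widely, with a number 37.3 percentage points lower from compound 1 to compound 2 (beyond the scatter) as well as the two steps above. Among the compounds with values here, the nearest comparison is compound 2, the only measured compound with fluorine in this group, which gives 9.08%. A fall is therefore expected, though with much uncertainty. The estimated change is a number 32.4 percentage points lower from compound 3 to compound 4 (beyond the scatter). Compound 4 is expected to give 26%, with an estimated range of 5% to 55%.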

Compound 4, percent growth inhibition at one concentration: 3.96%
Estimate against measurement, compound 4: 22 percentage points above, and the stated range ends above it.
By their numbers in this assay, from the lowest: compounds 4 and 2 (each within the scatter of the next); then compound 1; then compound 3.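

With 5-(trifluoromethyl)pyridin-2-yl, a ring with a hetero atom now sits on the sulfur, and in this assay this brings a number 54.4 percentage points lower from compound 3 to compound 4 (beyond the scatter) and also a number 42.4 percentage points lower from compound 1 to compound 4 (beyond the scatter), so the drop holds against both groups without fluorine. Against the only other fluorine-bearing compound, the step is a number 5.1 percentage points lower from compound 2 to compound 4 (within the scatter), which means that compound 2 and compound 4 cannot be told apart at the low end of this read-out, while compound 1 and compound 3, neither with fluorine, stand clearly higher. Nothing measured here gives a reason for this fall.

Going by these compounds, the ring nitrogen and the trifluoromethyl group enter together in compound 4, so their separate contributions remain unknown. A plain pyridin-2-yl and a phenyl ring carrying trifluoromethyl on the sulfur would be the comparisons that could pull them apart.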